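Lengthening the sulfamoyl chain on compound 1

This account rests on a few compounds, and the source may have more. Where it says the series, first, only, none or still open, it means among the compounds named here.

Compound 1 `CC(C)(C)c1ccc(-c2cc(N3CCC(CNS(N)(=O)=O)CC3)ncn2)cc1` carries a tert-butyl group on an aromatic carbon. Within the data shown here, in a functional assay on HT-29 cells (Homo sapiens) for antiproliferative activity, read by sulforhodamine B assay, with a stated time of 48 h (on this read-out lower numbers stand for stronger inhibition of growth and higher numbers for weaker inhibition of growth), compound 1 gives 8900 nM, the only plain number available here. Compound 2 `COc1ccc(-c2cc(N3CCC(CNS(N)(=O)=O)CC3)ncn2)cc1` reaches only the limit of this assay, > 100000 nM. The step of an at least 11-fold higher number from compound 1 to compound 2 (1.05 log units; beyond the scatter) changes the aromatic substituent, not the chain, so it does not bear on compound 3 `CC(C)(C)c1ccc(-c2cc(N3CCC(CCNS(N)(=O)=O)CC3)ncn2)cc1`. Compound 3 differs from compound 1 by (sulfamoylamino)methyl in place of sulfamoylamino on a saturated chain carbon bound to a saturated ring carbon. Among the measured compounds shown here, with no measured step touching this chain, compound 3 is expected to show no step beyond the scatter: a 1.0-fold higher number from compound 1 to compound 3 (0.00 log units; within the scatter). Compound 3 is therefore estimated at 9000 nM, within 3000 nM to 30000 nM.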

Compound 3, concentration for 50% growth inhibition: 10300 nM
Compound 3: middle estimate off by 1.1-fold (0.06 log units), on the low side, and the stated range covers the measured number.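

With the tert-butyl group kept, the chain change gives a 1.2-fold higher number from compound 1 to compound 3 (0.06 log units; within the scatter), the first step shown at this position rather than on the aromatic substituent. In this assay, this single lengthening therefore brings no gain or loss in growth inhibition that stands out from the scatter. Nothing measured here bears on the reason for this result. Still open, going by these compounds, is whether a longer chain, such as 3-(sulfamoylamino)propyl, would keep this level. On these data alone, an amine or a carboxylic acid in place of the sulfamoylamino group is equally open.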